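Aryl replacement on the ring nitrogen: outlook for compound 4

This account rests on a few compounds, and the source may have more. Where it says the series, first, only, none or still open, it means among the compounds named here.

Three members of the series share one core and differ only in the aryl group on the ring nitrogen. Compound 1 `COc1cccc(-n2cc(COc3cccc(NC(=O)Nc4ccc(Cl)c(C(F)(F)F)c4)c3)nn2)c1` carries 3-methoxyphenyl there, and in a functional assay on HepG2 cells (Homo sapiens) for inhibition, read by MTT assay, with a stated time of 72 h (a lower number here means a stronger inhibitor, a higher number a weaker inhibitor), compound 1 gives 1310 nM, the lowest of the three numbers. Compound 2 `N#Cc1ccccc1-n1cc(COc2cccc(NC(=O)Nc3ccc(Cl)c(C(F)(F)F)c3)c2)nn1` carries 2-cyanophenyl; in this assay compound 2 gives 1970 nM. Compound 3 `N#Cc1cccc(-n2cc(COc3cccc(NC(=O)Nc4ccc(Cl)c(C(F)(F)F)c4)c3)nn2)c1` carries 3-cyanophenyl; in this assay compound 3 gives 2760 nM. The steps among them are small: a 1.5-fold higher number from compound 1 to compound 2 (0.18 log units; within the scatter), a 2.1-fold higher number from compound 1 to compound 3 (0.32 log units; beyond the scatter), a 1.4-fold higher number from compound 2 to compound 3 (0.15 log units; within the scatter). Compound 1 thus sits at the low end of the numbers, separated from compound 3 by a modest step and from compound 2 by a step within the scatter.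

Compound 4 `O=C(Nc1cccc(OCc2cn(-c3ccc(Br)cc3)nn2)c1)Nc1ccc(Cl)c(C(F)(F)F)c1` is not yet measured. Relative to compound 1 it differs as follows. 4-bromophenyl in place of 3-methoxyphenyl on an aromatic nitrogen The measured steps that also exchange the aryl on the ring nitrogen bear on this: a 1.5-fold higher number from compound 1 to compound 2 (0.18 log units; within the scatter) and a 1.4-fold higher number from compound 2 to compound 3 (0.15 log units; within the scatter) stayed within the scatter, and the only step beyond it, a 2.1-fold higher number from compound 1 to compound 3 (0.32 log units; beyond the scatter), ran toward a higher number. Within the data shown here, a bromine in place of the methoxy group has no precedent in this set. A small rise is therefore expected, on the order of a 1.5-fold higher number from compound 1 to compound 4 (0.16 log units; within the scatter). Compound 4 is expected to give 1900 nM in this assay, with a range of 900 nM to 4000 nM.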

Compound 4, half-maximal inhibitory concentration: 2730 nM
Compound 4: the middle estimate sits 1.4-fold (0.16 log units) below what was measured; low and high end bracket the measured number.
By their numbers in this assay, from the lowest: compounds 1, 2, 4 and 3 (each within the scatter of the next, the first and the last beyond it).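

In this assay the exchange of 3-methoxyphenyl for 4-bromophenyl gives a 2.1-fold higher number from compound 1 to compound 4 (0.32 log units; beyond the scatter) and is a modest step, so two aryl groups, 4-bromophenyl and 3-cyanophenyl, now stand beyond the scatter from compound 1, while the 2-cyanophenyl of compound 2 goes against any such pattern by staying within it. Bromine is new to this position, yet the result does not separate it from either nitrile-bearing aryl group: the data show a 1.0-fold lower number from compound 3 to compound 4 (0.00 log units; within the scatter) and also a 1.4-fold higher number from compound 2 to compound 4 (0.14 log units; within the scatter) with both steps within the scatter, so compounds 2, 3 and 4 cannot be told apart in this assay. No measured evidence on these compounds accounts for the steps at this position.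

Compound 4 changes both the substituent and its place on the aryl group relative to compound 1, so the shown compounds do not tell which of the two carries the step; 3-bromophenyl and 4-methoxyphenyl would separate them. Also open, as far as these compounds go, is how the number responds to an aryl group carrying an amine or a carboxylic acid, or to a saturated chain in place of the aryl group on the ring nitrogen.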